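The source may hold more compounds than are shown below. What is called first, only, known or untested is meant among the compounds shown, and "the series" means these compounds.

Compound 2, `Cc1noc(NS(=O)(=O)c2cccc3c(NC(=O)C(C)C)cccc23)c1C`, gives 880 nM in an assay on VSM-A10 cells for antagonist activity at Endothelin-1 receptor (Rattus norvegicus) (on this read-out lower numbers stand for stronger inhibition and higher numbers for weaker inhibition), the lowest of the two numbers obtained in this set. Compound 3, `Cc1noc(NS(=O)(=O)c2cccc3c(N(C)C)cccc23)c1Cc1ccccc1`, gives 50000 nM in this assay, a gap from compound 2 that lies beyond the usual scatter. Compound 1, `Cc1noc(N(CC(=O)O)S(=O)(=O)c2ccc(N)cc2)c1C`, returns only a limit of the assay rather than a number, > 32000 nM; this is the situation described by the limit of > 32000 nM in this assay, at which 1 of the 3 values shown sits.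

Compound 4, `Cc1noc(NS(=O)(=O)c2cccc3c(CN(C)C)cccc23)c1C`, has not yet been measured in this assay. It differs from compound 2 in one place: (dimethylamino)methyl in place of (isopropylcarbonyl)amino on an aromatic carbon. Among the compounds with values here, no measured pair in this set isolates that change, so the expectation rests on the whole spread of the numbers. Compound 3, which also carries a dimethylamino-bearing substituent on the fused ring system while differing from compound 2 elsewhere as well, sits far above compound 2, and this makes a loss of potency for compound 4 seem more likely than a gain. The step from compound 2 to compound 4 is therefore expected to be a 9.1-fold higher number from compound 2 to compound 4 (0.96 log units; beyond the scatter), a shift beyond the scatter toward weaker inhibition. Compound 4 is estimated to give about 8000 nM in this assay, within a range from 1500 nM to 40000 nM.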

Compound 4, half-maximal inhibitory concentration: 2800 nM
Beside the measured number, compound 4's estimate is 2.9-fold (0.46 log units) above it, within the range that was stated.
By their numbers in this assay, from the lowest: compound 2; then compound 4; then compound 3.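

Within the data shown here, the change from (isopropylcarbonyl)amino to (dimethylamino)methyl on this aromatic carbon gives the first single-place comparison at this position in this assay: a 3.2-fold higher number from compound 2 to compound 4 (0.50 log units; beyond the scatter). Among these compounds, the step is modest, so at this position a group without a hydrogen-bond donor or a carbonyl keeps a measured value in the same assay, whereas the earlier compounds differed in more than one place and could not show this. No measurement shown bears on the cause of this step.

From the compounds shown here alone, whether the step follows from losing the carbonyl, from losing the hydrogen-bond donor or from the entering amine itself remains open. Also open, going by these compounds, is how a carboxylic acid or a longer alkyl chain on this aromatic carbon would read in this assay.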